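Replacing sec-butyl with a benzyl ester side chain

The source may hold more compounds than are shown below. What is called first, only, known or untested is meant among the compounds shown, and "the series" means these compounds.

Compound 2 `CC[C@H](C)[C@H](NC(=O)CN(c1ncnc2c1ncn2C1CCCCO1)C1CC1)C(=O)OCc1ccccc1` gives 27.4% in a functional assay on the whole organism (Tail, strain ICR) with Mus musculus as the target, in the tail flick test, with a stated time of 60 min, at a dose of 25 umol/kg by the oral route (a higher number here means a stronger effect of the compound at the dose given, a lower number a weaker effect), the lowest of the three numbers, though both other compounds lie within the scatter of it: compound 1 `CC(C)[C@H](NC(=O)CN(c1ncnc2c1ncn2C1CCCCO1)C1CC1)C(=O)OCc1ccccc1` at 34.9% and compound 3 `NC(=O)C[C@H](NC(=O)CN(c1nc(Cl)nc2[nH]cnc12)C1CC1)C(=O)OCc1ccccc1` at 36.4%. Compound 4 `O=C(CN(c1ncnc2c1ncn2C1CCCCO1)C1CC1)N[C@@H](CCC(=O)OCc1ccccc1)C(=O)OCc1ccccc1` differs from compound 2 by 2-(benzyloxycarbonyl)ethyl in place of sec-butyl on a saturated chain carbon bound to an amide-type nitrogen and a carbonyl carbon. Going by the values given here, the single measured step that bears on this side chain, a number 7.5 percentage points lower from compound 1 to compound 2 (within the scatter), stayed within the scatter; compound 3 carries yet another side chain on a different core, and its number is close to those of compounds 1 and 2. Nothing here points to a shift beyond the scatter, so the step of a number 4.6 percentage points higher from compound 2 to compound 4 (within the scatter) is expected to be small. Compound 4 is therefore estimated at 32%, in a range from 15% to 50%.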

Compound 4, a percentage reported as activity, at one dose (the size of the read-out at that dose, not a potency): 34.7%
For compound 4 the middle estimate is 2.7 percentage points below the measured one; the measured number falls inside the stated range.
By their numbers in this assay, from the lowest: compounds 2, 4, 1 and 3 (each within the scatter of the next).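

In this assay, 2-(benzyloxycarbonyl)ethyl, with 12 heavy atoms and an aromatic ring, is accepted on the saturated chain carbon bound to an amide-type nitrogen and a carbonyl carbon. Both a number 7.3 percentage points higher from compound 2 to compound 4 (within the scatter) and a number 0.2 percentage points lower from compound 1 to compound 4 (within the scatter) stay inside the scatter, so this much larger change at the position moves the read-out no further than the methyl step did. From the compounds shown here alone, whether a free carboxylic acid in place of the benzyl ester, or an amine on the chain, would leave the number equally unchanged remains open. No measurement given here accounts for this result.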